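The source may hold more compounds than are shown below. What is called first, only, known or untested is meant among the compounds shown, and "the series" means these compounds.

Compound 1, `CC1=C(C(=O)OCC(C)C)C(c2cccs2)NC(=O)N1`, gives 11% in an assay on membranes from HeLa cells for displacement of a labelled ligand from adenosine receptor A3 (Homo sapiens), read by scintillation counting, with a stated time of 180 min, tested at 1 uM; on this read-out lower numbers stand for less inhibition and higher numbers for more inhibition at the one concentration tested (going by the name of the read-out). Compound 2, `CC1=C(C(=O)OC(C)(C)C)C(c2cccs2)NC(=O)N1`, gives 7% in this assay. Compound 3, `CC1=C(C(=O)OCC(C)C)C(c2ccoc2)NC(=O)N1C`, gives 16% in this assay.

Compounds 1 and 2 share one core and differ in a single place: tert-butyl in place of isobutyl on an oxygen next to a carbonyl group. This change made a step of a number 4 percentage points lower from compound 1 to compound 2 (within the scatter), so the two values are to be read as the same within the usual scatter of this measurement. Compound 3 carries a different core; how the core of compound 3 differs from the core of compound 1 is not broken down here. Its value stands highest of the three, but its steps to compound 1 and to compound 2 both lie within the scatter, so no order among the three can be claimed.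

Compound 4, `CC1=C(C(=O)OC(C)(C)C)C(c2ccoc2)NC(=O)N1C`, has not yet been measured in this assay. It differs from compound 3 in exactly the same way that compound 2 differs from compound 1: tert-butyl in place of isobutyl on an oxygen next to a carbonyl group. Both "place" descriptions read alike word for word, so this is the same change on a second core. Since compound 1 to compound 2 gave a number 4 percentage points lower from compound 1 to compound 2 (within the scatter), a step of about the same size is expected from compound 3 to compound 4, namely a number 4 percentage points lower from compound 3 to compound 4 (within the scatter). On that basis compound 4 is estimated to give 12% in this assay, most likely between 3% and 22%.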

Compound 4, a percentage reported as inhibition, at one concentration (the size of the read-out at that concentration, not a potency): 12%
For compound 4 middle estimate and measured number coincide at the digits printed; the measured number falls inside the stated range.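

On the second core, tert-butyl in place of isobutyl gives a step of a number 4 percentage points lower from compound 3 to compound 4 (within the scatter) in this assay. Set beside the same change on the first core, the two steps agree: the same change on two cores in this assay, a number 4 percentage points lower (within the scatter) from compound 1 to compound 2 and a number 4 percentage points lower (within the scatter) from compound 3 to compound 4, 0 percentage points apart, within the scatter of two such steps. This shows that the change reads the same on these two cores, but each step on its own cannot be told apart from no change at all, so the agreement is not evidence of a real effect that carries from one core to another, and it covers only these two cores at the one concentration tested.

The compounds shown place only isobutyl or tert-butyl on this oxygen, so it remains open whether a longer chain or a benzyl group there, or a carboxylic acid or an amide in place of the whole isobutoxycarbonyl group, would move the number by more than the scatter. As far as these compounds go, it also remains open whether the swap from isobutyl to tert-butyl would read the same on a core that gives a much higher number in this assay, where a real difference would be easier to see.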